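Swapping the Pyridyl Arm for Thiophene

This account rests on a few compounds, and the source may have more. Where it says the series, first, only, none or still open, it means among the compounds named here.

For the measured compounds named here, compound 2 `Cn1cc(/C=C2/C(=O)Nc3ccccc32)c2cc(Nc3nccc(-c4cccnc4)n3)ccc21` gives the lowest of the two numbers so far in a functional assay on PA-1 cells (Homo sapiens) for cytotoxicity, read by MTT assay, with a stated time of 48 h; on this read-out higher numbers stand for weaker inhibition and lower numbers for stronger inhibition: compound 2 shows 18100 nM, whereas compound 1 `Cn1cc(/C=C2/C(=O)Nc3ccccc32)c2cc(Nc3nccc(-c4ccc(C(F)(F)F)cc4)n3)ccc21` shows 63900 nM, the step being a 3.5-fold lower number from compound 1 to compound 2 (0.55 log units; beyond the scatter). Compound 3 `Cn1cc(/C=C2/C(=O)Nc3ccccc32)c2cc(Nc3nccc(-c4cccs4)n3)ccc21` differs from compound 2 by thiophen-2-yl in place of pyridin-3-yl on an aromatic carbon. Going by the values given here, only that one measured step bears on this change, and it concerned a different aromatic group, so it guides weakly. A thiophen-2-yl is expected to land between the two measured compounds, giving an estimated 1.7-fold higher number from compound 2 to compound 3 (0.22 log units; within the scatter). Compound 3 is therefore estimated at 30000 nM, within a range of 10000 nM to 90000 nM.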

Compound 3, half-maximal inhibitory concentration: 7940 nM
For compound 3 the middle estimate is 3.8-fold (0.58 log units) above the measured one; the measured number lies below the stated range.
By their numbers in this assay, from the lowest: compound 3; then compound 2; then compound 1.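

In this assay the thiophen-2-yl group goes beyond both earlier groups at this position, with a 2.3-fold lower number from compound 2 to compound 3 (0.36 log units; beyond the scatter) and with an 8.0-fold lower number from compound 1 to compound 3 (0.91 log units; beyond the scatter) across the wider change. A five-membered aromatic ring with sulfur can therefore stand here in place of either six-membered ring without loss, and the three groups now rank thiophen-2-yl, pyridin-3-yl, 4-(trifluoromethyl)phenyl from the lowest number. Nothing available explains this order. As far as these compounds go, it remains open whether furan-2-yl, thiophen-3-yl or a saturated amine such as morpholine would lower the number further.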